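The source may hold more compounds than are shown below. What is called first, only, known or untested is meant among the compounds shown, and "the series" means these compounds.

In a functional assay on HCT-116 cells (Homo sapiens) for inhibition, read by MTT assay, with a stated time of 72 h, in the presence of a further agent that is not named here (on this read-out lower numbers stand for an effect already at smaller amounts and higher numbers for an effect only at larger amounts of compound), compound 1 `Cc1cc(NC(=O)Nc2cc(Cl)nc(Cl)c2)n(C)n1` gives 94200 nM while compound 2 `O=C(Nc1cc(Cl)nc(Cl)c1)Nc1cc(Cl)nc(Cl)c1` gives 180 nM and compound 3 `COc1cc(NC(=O)Nc2cc(Cl)nc(Cl)c2)cc(Cl)n1` gives 11200 nM as the second highest of the three numbers. Compound 4 `CC(C)Oc1cc(NC(=O)Nc2cc(Cl)nc(Cl)c2)cc(Cl)n1` awaits measurement and differs from compound 3 by isopropyl in place of methyl on an oxygen on an aromatic ring in an exchange of isopropyl in place of methyl on an oxygen on an aromatic ring. For the measured compounds named here, the one measured step touching that place is a 62-fold higher number from compound 2 to compound 3 (1.79 log units; beyond the scatter) for methoxy in place of chloro on an aromatic carbon. Going by the values given here, it is large but exchanges another group, so no direction follows from it, and no measured step alters the group on that oxygen. Only a small step is expected in this assay and the estimate amounts to a 1.3-fold higher number from compound 3 to compound 4 (0.10 log units; within the scatter) within the scatter. The estimate for compound 4 is 14000 nM with an expected range from 4000 nM to 50000 nM in this series.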

Compound 4, half-maximal effective concentration: 5230 nM
Beside the measured number, compound 4's estimate is 2.7-fold (0.43 log units) above it; the measured number falls inside the stated range.
By their numbers in this assay, from the lowest: compound 2; then compound 4; then compound 3; then compound 1.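

In this assay, for the compounds shown here, the change from methoxy to isopropoxy gives a 2.1-fold lower number from compound 3 to compound 4 (0.33 log units; beyond the scatter) as the first measured step for the group on this oxygen, so enlarging that group from methyl to isopropyl moves the number down rather than up. Isopropoxy still stays well short of chloro on that aromatic carbon, with a 29-fold higher number from compound 2 to compound 4 (1.46 log units; beyond the scatter) as the remaining gap. No data here bear on the reason for either step. From the compounds shown here alone, whether a longer chain such as n-butoxy continues this direction remains open. So does how an amine on that aromatic carbon would compare with chloro.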